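This account rests on a few compounds, and the source may have more. Where it says the series, first, only, none or still open, it means among the compounds named here.

Measured compounds:
Compound 1 `CN(C)CCn1c(=O)sc2cc(S(=O)(=O)N(C)c3ccccc3)ccc21`: in an ADME assay on SH-SY5Y cells (Homo sapiens) for inhibition, read by MTT assay, with a stated time of 72 h (on this read-out higher numbers stand for weaker inhibition and lower numbers for stronger inhibition), compound 1 gives 91000 nM.
Compound 2 `CN(c1ccccc1)S(=O)(=O)c1ccc2c(c1)sc(=O)n2CCN1CCCC1`: compound 2 gives 49500 nM.
Compound 3 `CN(C)CCn1c(=O)sc2cc(S(=O)(=O)Nc3cccc4ccccc34)ccc21`: compound 3 gives 45700 nM.

Compound 2 arises from compound 1 by one change, (pyrrolidin-1-yl in place of dimethylamino on a saturated chain carbon, two bonds along the chain from an aromatic nitrogen), and this brought a 1.8-fold lower number from compound 1 to compound 2 (0.26 log units; within the scatter). Compound 4 `O=c1sc2cc(S(=O)(=O)Nc3cccc4ccccc34)ccc2n1CCN1CCCC1` is not yet measured; it arises from compound 3 by the same change, (pyrrolidin-1-yl in place of dimethylamino on a saturated chain carbon, two bonds along the chain from an aromatic nitrogen), at the same place. The difference between the core of compound 1 and the core of compound 3 is not broken down here. Within the data shown here, since the one earlier step stayed within the scatter, a step of similar modest size is expected from compound 3 to compound 4 in this assay, namely a 1.5-fold lower number from compound 3 to compound 4 (0.18 log units; within the scatter), resting only on that single precedent. Compound 4 is therefore estimated at 30000 nM, expected to fall between 12000 nM and 80000 nM.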

Compound 4, half-maximal inhibitory concentration: 68600 nM
Estimate against measurement, compound 4: 2.3-fold (0.36 log units) below; measured number inside the range.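

In this assay, putting pyrrolidin-1-yl in place of dimethylamino gives a 1.5-fold higher number from compound 3 to compound 4 (0.18 log units; within the scatter), which lies within the scatter, as does the earlier step on the core of compound 1. Set side by side, however, the two steps do not agree: the same change on two cores in this assay, a 1.8-fold lower number (0.26 log units; within the scatter) from compound 1 to compound 2 and a 1.5-fold higher number (0.18 log units; within the scatter) from compound 3 to compound 4, 2.8-fold (0.44 log units) apart, beyond the scatter of two such steps. So the effect of this change on one core cannot simply be carried over to the other, although two pairs do not show which part of the cores is responsible or how the change would behave on any further core.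

The compounds shown leave open how a diethylamino group would read in this assay on either core. They also leave open whether a longer chain carrying the same amines would keep the gap between the two cores.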